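From nitro to fluoro: what size of step to expect

This account rests on a few compounds, and the source may have more. Where it says the series, first, only, none or still open, it means among the compounds named here.

Compound 1 `Oc1ccc(-c2nc3cc(C(F)(F)F)ccc3[nH]2)cc1`: > 100000 nM, a limit of the assay and not a number
Compound 2 `O=[N+]([O-])c1ccc(-c2nc3cc(C(F)(F)F)ccc3[nH]2)cc1`: 45000 nM
Compound 3 `O=[N+]([O-])c1ccc(-c2nc3cc(C(F)(F)F)ccc3[nH]2)c([N+](=O)[O-])c1`: 25000 nM

All three results come from an ADME assay on Vero cells (Chlorocebus sabaeus) for cytotoxicity; on this read-out lower numbers stand for higher toxicity in this test and higher numbers for lower toxicity in this test. Compound 2 gives 45000 nM, and compound 3 at 25000 nM lies within the scatter of compound 2. Compound 1 sits at the limit of the assay.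

The next compound to be measured is compound 4 `Fc1ccc(-c2nc3cc(C(F)(F)F)ccc3[nH]2)cc1`. It differs from compound 2 as follows: fluoro in place of nitro on an aromatic carbon. Fluoro takes the place of nitro on an aromatic carbon, para to a large group.

For the measured compounds named here, two measured steps bear on this change, though neither involves fluoro. The closer one is an at least 2.2-fold lower number from compound 1 to compound 2 (0.34 log units; beyond the scatter), where nitro took the place of hydroxy on the same aromatic carbon. The other is a 1.8-fold lower number from compound 2 to compound 3 (0.26 log units; within the scatter), where a further nitro took the place of hydrogen on an aromatic carbon.

Compound 4 loses the nitro that entered in an at least 2.2-fold lower number from compound 1 to compound 2 (0.34 log units; beyond the scatter), so a small move towards a higher number is expected, probably not beyond the scatter. The estimated step is a 1.3-fold higher number from compound 2 to compound 4 (0.12 log units; within the scatter). Compound 4 is expected to give 60000 nM, with an estimated range of 25000 nM to 100000 nM.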

Compound 4, half-maximal cytotoxic concentration: 60000 nM
Beside the measured number, compound 4's estimate shows no gap at the digits printed; low and high end bracket the measured number.
By their numbers in this assay, from the lowest: compounds 3, 2 and 4 (each within the scatter of the next, the first and the last beyond it). At a limit, above all of these: compound 1.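

At this aromatic carbon, para to a large group, this assay now has a comparison of fluoro with nitro, and a 1.3-fold higher number from compound 2 to compound 4 (0.12 log units; within the scatter) shows that this exchange leaves the two numbers indistinguishable. For the compounds shown here, the earlier steps compared nitro only with hydroxy or hydrogen, so this is the first sign that nitro can be removed here without a clear change, provided fluoro takes its place. The comparison of fluoro with hydroxy is less firm, since an at least 1.6-fold lower number from compound 1 to compound 4 (0.22 log units; that floor lies within the scatter) gives only a floor, and compound 1 gives > 100000 nM, a limit of the assay and not a number, which leaves the full size of that step unknown: the limit of > 100000 nM in this assay, at which 1 of the 4 values shown sits.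

The compounds shown carry only hydroxy, nitro or fluoro at this carbon, so it remains open whether an amine, a carboxylic acid or a methoxy group would give a number clearly apart from theirs. Also open, from the compounds shown here alone, is whether fluoro and nitro would remain this close with the further nitro of compound 3 present, or at another carbon of the same ring.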